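A few compounds are considered here, and "the series" means these few. Any claim that something is new, unique, unknown or untested is made for them only; others in the source may bear on it.

Measured compounds:
compound 1 `Cc1ccc(-c2ccnc(Nc3ccc4c(c3)c(/C=C3/C(=O)Nc5ccccc53)cn4C)n2)cc1` — in a functional assay on PA-1 cells (Homo sapiens) for cytotoxicity, read by MTT assay, with a stated time of 48 h (a higher number here means a weaker inhibitor, a lower number a stronger inhibitor), compound 1 sits at the assay limit of > 100000 nM.
compound 2 `Cn1cc(/C=C2/C(=O)Nc3ccccc32)c2cc(Nc3nccc(-c4ccc(F)cc4)n3)ccc21` — in this assay compound 2 gives 31800 nM.

Compound 1 stands only at a limit in this assay, so no number is known for it (the limit of > 100000 nM in this assay, at which 1 of the 2 values shown sits). Among the compounds with values here, the single measured step, an at least 3.1-fold lower number from compound 1 to compound 2 (0.49 log units; beyond the scatter), shows that a change on the same aromatic carbon can move the number beyond the scatter. The step to compound 3 `Cn1cc(/C=C2/C(=O)Nc3ccccc32)c2cc(Nc3nccc(-c4cccs4)n3)ccc21` is larger: thiophen-2-yl in place of 4-methylphenyl on an aromatic carbon. Within the data shown here, no measured pair covers the exchange of a phenyl ring for a five-membered ring, so the expectation leans on compound 2 alone. The estimate is that compound 3 will land near the value of compound 2, with a sizeable chance that only a limit is reported. Compound 3 is expected at 45000 nM, between 12000 nM and 150000 nM. This amounts to an expected step of an at least 2.2-fold lower number from compound 1 to compound 3 (0.34 log units; beyond the scatter).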

Compound 3, half-maximal inhibitory concentration: 7940 nM
For compound 3 the middle estimate is 5.7-fold (0.75 log units) above the measured one; the measured number lies below the stated range.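

Compound 3 shows that this position responds to the ring itself, not only to the group carried on a phenyl ring: in this assay, thiophen-2-yl in place of 4-methylphenyl brings an at least 12-fold lower number from compound 1 to compound 3 (1.10 log units; beyond the scatter). Against the fluorinated ring, the same exchange brings a 4.0-fold lower number from compound 2 to compound 3 (0.60 log units; beyond the scatter), which makes compound 3 the strongest of the three. The first of these steps gives only a minimum size, since compound 1 stands at a limit: the limit of > 100000 nM in this assay, at which 1 of the 3 values shown sits.

The compounds shown leave open whether this result belongs to the sulfur atom or to the five-membered ring as such, a question that a furan-2-yl group would help to separate. From the compounds shown here alone, it also remains open how an amine or a carboxylic acid on this ring would read.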